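This account rests on a few compounds, and the source may have more. Where it says the series, first, only, none or still open, it means among the compounds named here.

Within the data shown here, in a functional assay on K562 cells (Homo sapiens) for antiproliferative activity, with a stated time of 72 h (on this read-out lower numbers stand for stronger inhibition and higher numbers for weaker inhibition), compound 1 `OC[C@H]1O[C@@H](n2cnc3c(NCc4ccc(F)cc4)ncnc32)[C@H](O)[C@@H]1O` gives 2700 nM, the only measured number here. Compound 2 `COc1cc(CNc2ncnc3c2ncn3[C@@H]2O[C@H](CO)[C@@H](O)[C@H]2O)cc(OC)c1` gives only a limit, > 166000 nM. Among the measured compounds shown here, the single measured step, an at least 61-fold higher number from compound 1 to compound 2 (1.78 log units; beyond the scatter), runs up to the limit of > 166000 nM in this assay, at which 1 of the 2 values shown sits. Compound 3 `Cc1ccc(O)c(CNc2ncnc3c2ncn3[C@@H]2O[C@H](CO)[C@@H](O)[C@H]2O)c1` differs from compound 1 by 2-hydroxy-5-methylphenyl in place of 4-fluorophenyl on a saturated chain carbon bound to a nitrogen on an aromatic ring. That change swaps out the same 4-fluorophenyl as the measured step did, so a weakening well beyond the scatter is expected, though one smaller than that seen for compound 2 cannot be excluded. Compound 3 is therefore estimated at 30000 nM, within 5000 nM to 170000 nM. The expected step is an 11-fold higher number from compound 1 to compound 3 (1.05 log units; beyond the scatter).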

Compound 3, half-maximal inhibitory concentration: 16500 nM
The estimate for compound 3 lay 1.8-fold (0.26 log units) above the measured number; the measured number falls inside the stated range.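

In this assay, the change at this place, on a saturated chain carbon bound to a nitrogen on an aromatic ring, now has a fully measured step: 2-hydroxy-5-methylphenyl in place of 4-fluorophenyl gives a 6.1-fold higher number from compound 1 to compound 3 (0.79 log units; beyond the scatter). Replacing 4-fluorophenyl therefore does not weaken the number by the same amount each time, as 2-hydroxy-5-methylphenyl in place of 3,5-dimethoxyphenyl gives an at least 10-fold lower number from compound 2 to compound 3 (1.00 log units; beyond the scatter). That second step starts from a limit for compound 2, not a number: the limit of > 166000 nM in this assay, at which 1 of the 3 values shown sits.

The compounds shown leave open whether the hydroxy or the methyl of 2-hydroxy-5-methylphenyl accounts for this difference. They also leave open how a 4-aminophenyl, a 4-carboxyphenyl or a longer chain would read at this place.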